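Piperidine to ethylpiperazine in a bis-sulfonamide series

The source may report more compounds than this note shows. Statements on the series, on what has been measured and on what is new or still open speak of the compounds shown alone.

Compound 1 `COc1ccc(S(=O)(=O)N(CC(N)=O)c2ccc(N(CC(N)=O)S(=O)(=O)c3ccc(NC(=O)CCN4CCCCC4)cc3)c3ccccc23)cc1`: in a functional assay on cells (Peritoneal macrophage, Mus musculus) for cytotoxicity, with a stated time of 24 h (on this read-out higher numbers stand for lower toxicity in this test and lower numbers for higher toxicity in this test), compound 1 gives only the limit > 100000 nM.
Compound 2 `COc1ccc(S(=O)(=O)N(CC(N)=O)c2ccc(N(CC(N)=O)S(=O)(=O)c3ccc(NC(=O)CCN4CCC(C)CC4)cc3)c3ccccc23)cc1`: in this assay compound 2 gives only the limit > 100000 nM.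

Both values sit at the limit of > 100000 nM in this assay, at which 2 of the 2 values shown sit, so the step that the two limits leave unreadable from compound 1 to compound 2 has no readable size and compound 2 stands at that limit rather than at a number. Compound 3 `CCN1CCN(CCCC(=O)Nc2ccc(S(=O)(=O)N(CC(N)=O)c3ccc(N(CC(N)=O)S(=O)(=O)c4ccc(OC)cc4)c4ccccc34)cc2)CC1` differs from compound 2 by (4-ethylpiperazin-1-yl)methyl in place of 4-methylpiperidin-1-yl on a saturated chain carbon, two bonds along the chain from a carbonyl carbon. Going by the values given here, no measured step bears on this change; the single recorded step offers no size to carry over. Compound 3 is therefore expected to stay at the limit as well, with an estimate of 200000 nM and a range of 60000 nM to 700000 nM, the expected step being a step that the limit leaves unreadable from compound 2 to compound 3, none beyond scatter.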

Compound 3, half-maximal cytotoxic concentration: > 100000 nM
Compound 3: a limit, no number; the forecaster's own chance of this, stated with the estimate: 85%; the middle value does not contradict the limit.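

Going by these compounds alone, compound 1, compound 2 and compound 3 all sit at a limit in this assay and not at a number, so no step among them can be read. The compounds shown leave open whether their side chains differ in this assay at all.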